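A few compounds are considered here, and "the series" means these few. Any claim that something is new, unique, unknown or untested is made for them only; others in the source may bear on it.

Values in an ADME assay on MDCK cells (Canis lupus familiaris) for cytotoxicity, read by MTT assay, with a stated time of 24 h; on this read-out higher numbers stand for lower toxicity in this test and lower numbers for higher toxicity in this test:
- Compound 1 `O=[N+]([O-])c1ccc(S(=O)(=O)NCc2cccs2)cc1`: 133000 nM
- Compound 2 `O=[N+]([O-])c1ccc(S(=O)(=O)NCc2ccc(Cl)s2)cc1`: 128000 nM
- Compound 3 `O=[N+]([O-])c1ccc(S(=O)(=O)NCc2csc3ccccc23)cc1`: > 191000 nM

In this assay, compound 3 gives > 191000 nM, which is a limit and not a number. The next compound to be tested, compound 4 `O=S(=O)(NCc1csc2ccccc12)c1ccc(Cl)cc1`, keeps the rest of compound 3 but carries chloro in place of nitro on an aromatic carbon.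

Going by the values given here, no measured step replaces nitro, so the evidence here is thin. Among the compounds with values here, the one measured step that brings in chloro puts it in place of hydrogen, and it shows a 1.0-fold lower number from compound 1 to compound 2 (0.02 log units; within the scatter). That change left the value of compound 1 at 133000 nM and that of compound 2 at 128000 nM, within the scatter of each other. On this basis, no step beyond the scatter is expected in this assay. The expected step is an at least 1.2-fold lower number from compound 3 to compound 4 (0.10 log units; that floor lies within the scatter). The estimated value for compound 4 is 150000 nM, with an expected range of 70000 nM to 320000 nM.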

Compound 4, half-maximal cytotoxic concentration: 69600 nM
Compound 4: the middle estimate sits 2.2-fold (0.33 log units) above what was measured, outside the stated range (below it).
By their numbers in this assay, from the lowest: compounds 4, 2 and 1 (each within the scatter of the next). At a limit, above all of these: compound 3.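

In this assay, going by these compounds alone, the swap of nitro for chloro on the six-membered aromatic ring gives an at least 2.7-fold lower number from compound 3 to compound 4 (0.43 log units; beyond the scatter), so this position, para to a large group, is the first place here where a change moves the number beyond the scatter, towards higher toxicity in this test. The earlier chloro step, made at a different place in the molecule, gave a 1.0-fold lower number from compound 1 to compound 2 (0.02 log units; within the scatter), so chloro in itself does not carry a shift from one place to another. The size of the new step is only a floor, because compound 3 stands at a limit and not a number: the limit of > 191000 nM in this assay, at which 1 of the 4 values shown sits.

On these data alone, what stays open is whether the loss of nitro or the arrival of chloro drives the step, since both happen at once. Plain hydrogen, an amine or a carboxylic acid at this position would help separate the two, and the same swap on the core of compound 1 would test whether the step holds there.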